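Naphthalen-1-yl in Place of 4-Methylphenyl: An Estimate

This account rests on a few compounds, and the source may have more. Where it says the series, first, only, none or still open, it means among the compounds named here.

Compound 1 `COc1ccc(-n2nc(Sc3ccc(Cl)cc3)cc(CC[C@@H](C)NC(=O)[C@H]3CNCC[C@@H]3c3cccc(F)c3)c2=O)cc1` gives 490 nM in an assay on CHO cells for binding affinity to Melanocortin receptor 4 (Homo sapiens); a higher number here means a weaker inhibitor, a lower number a stronger inhibitor.
Compound 2 `COc1ccc(-n2nc(Sc3ccc(Cl)cc3)cc(CC[C@@H](C)NC(=O)[C@H]3CNCC[C@@H]3c3cccc(C(F)(F)F)c3)c2=O)cc1` gives 100 nM in this assay.
Compound 3 `COc1ccc(-n2nc(Sc3ccc(Cl)cc3)cc(CC[C@@H](C)NC(=O)[C@H]3CNCC[C@@H]3c3ccc(C)cc3)c2=O)cc1` gives 4.7 nM in this assay.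

Compound 3 has the lowest number of the three, and both of its steps from the others lie beyond the scatter: a 100-fold lower number from compound 1 to compound 3 (2.02 log units; beyond the scatter) and a 21-fold lower number from compound 2 to compound 3 (1.33 log units; beyond the scatter). Within this small set the group on the saturated ring carbon clearly matters, since a 4.9-fold lower number from compound 1 to compound 2 (0.69 log units; beyond the scatter) already moves the number while leaving everything else in place.

Compound 4 `COc1ccc(-n2nc(Sc3ccc(Cl)cc3)cc(CC[C@@H](C)NC(=O)[C@H]3CNCC[C@@H]3c3cccc4ccccc34)c2=O)cc1` differs from compound 3 in one place: naphthalen-1-yl in place of 4-methylphenyl on a saturated ring carbon.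

No measured step exchanges a single-ring aromatic group for a fused two-ring one, so the three steps shown only tell that this position is sensitive, not which way a larger group will move the number. Because a 21-fold lower number from compound 2 to compound 3 (1.33 log units; beyond the scatter) and a 100-fold lower number from compound 1 to compound 3 (2.02 log units; beyond the scatter) show that departures from 4-methylphenyl have so far raised the number, compound 4 is expected to give a somewhat higher number, with a 3.2-fold higher number from compound 3 to compound 4 (0.50 log units; beyond the scatter) as the estimated step. The estimate for compound 4 in this assay is 15 nM, with a range from 3 nM to 80 nM.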

Compound 4, half-maximal inhibitory concentration: 89 nM
The estimate for compound 4 lay 5.9-fold (0.77 log units) below the measured number; the whole stated range lies below it.
By their numbers in this assay, from the lowest: compound 3; then compounds 4 and 2 (each within the scatter of the next); then compound 1.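

At this position, a second fused aromatic ring does not preserve the low number seen with a single ring bearing a methyl group: naphthalen-1-yl in place of 4-methylphenyl gives a 19-fold higher number from compound 3 to compound 4 (1.28 log units; beyond the scatter) in this assay and is a large step. The new group also sits level with 3-(trifluoromethyl)phenyl, as a 1.1-fold lower number from compound 2 to compound 4 (0.05 log units; within the scatter) shows, while it keeps an advantage over 3-fluorophenyl, with a 5.5-fold lower number from compound 1 to compound 4 (0.74 log units; beyond the scatter) as a modest step beyond the scatter. Among these four compounds, then, 4-methylphenyl alone gives the lowest number, every other group tried here gives a clearly higher one, and nothing available explains these differences.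

On these data alone, whether naphthalen-2-yl, which joins the same two rings to the saturated ring carbon through a different atom, would give a number nearer that of compound 3 or that of compound 4 stays open. Also open, as far as these compounds go, is whether the methyl group of compound 3 owes its result to being a methyl or to where it sits on the ring, a question that 3-methylphenyl and 4-chlorophenyl could help to separate.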